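This account rests on a few compounds, and the source may have more. Where it says the series, first, only, none or still open, it means among the compounds named here.

Measured compounds:

- compound 1 `O=C(O)CCCOc1ccc(-c2cccc(Oc3ccccc3)c2)cc1`: 6800 nM
- compound 2 `O=C(O)CCCOc1ccc(-c2cc(OC(F)(F)F)ccc2F)cc1`: 4220 nM
- compound 3 `O=C(O)CCCOc1ccc(-c2cc(Oc3ccccc3)ccc2F)cc1`: 3590 nM

All three were tested in a functional assay on isolated protein for agonist activity at Free fatty acid receptor 1 (Homo sapiens), read by HTRF and inositol phosphate accumulation, with a stated time of 60 min; a lower number here means that less compound is needed, a higher number that more compound is needed for the effect. Compound 1 gives the highest of the three numbers, but its gaps to compound 2 and to compound 3 both stay within the scatter, so the three cannot be ranked on these values. The two single-point steps that were measured, a 1.9-fold lower number from compound 1 to compound 3 (0.28 log units; within the scatter) and a 1.2-fold lower number from compound 2 to compound 3 (0.07 log units; within the scatter), are likewise both within the scatter.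

Compound 4 `Cc1ccc(Oc2cccc(-c3ccc(OCCCC(=O)O)cc3)c2)cc1` has not yet been measured. It differs from compound 1 in one place: methyl in place of hydrogen on an aromatic carbon, on an aromatic carbon para to a large group, so that the phenoxy becomes a 4-methylphenoxy. Within the data shown here, no measured step touches that outer ring, and the two steps that exist elsewhere in the shared core were both small. An estimated step of a 1.4-fold lower number from compound 1 to compound 4 (0.13 log units; within the scatter) is therefore expected, with no change beyond the scatter. Compound 4 is estimated at 5000 nM in this assay, in an expected range from 2000 nM to 15000 nM.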

Compound 4, half-maximal effective concentration: > 9950 nM
Compound 4 ended at the assay's limit; the forecaster's own chance of this, stated with the estimate: 5%; middle value at least 1.9-fold (0.29 log units) from the limit.
By their numbers in this assay, from the lowest: compounds 3, 2 and 1 (each within the scatter of the next). At a limit, above all of these: compound 4.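

Compound 4 is the only compound shown with a change on the outer ring, and in this assay compound 4 gives > 9950 nM, which is a limit of the assay and not a number. From the compounds shown here alone, the change from phenoxy to 4-methylphenoxy, on an aromatic carbon para to a large group, gives an at least 1.4-fold higher number from compound 1 to compound 4 (0.16 log units; that floor lies within the scatter): a methyl here shows no sign of lowering the number, but only a floor is known for the step, and the true size remains unknown. Compound 4 also stands alone at this limit among the compounds shown: the limit of > 9950 nM in this assay, at which 1 of the 4 values shown sits.

Going by these compounds, whether the methyl raises the number beyond the scatter therefore remains open. So does the effect of a chloro, a methoxy or a hydroxyl at this same place on the outer ring.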